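The source may hold more compounds than are shown below. What is called first, only, known or untested is meant among the compounds shown, and "the series" means these compounds.

For the measured compounds named here, in a functional assay on Hep 3B2 cells (Homo sapiens) for antiproliferative activity, read by MTT assay, with a stated time of 24 h (on this read-out higher numbers stand for weaker inhibition and lower numbers for stronger inhibition), compound 1 `COc1ccc2nc(C(=O)Nc3ccc(-c4ccccc4)cc3)c(C)c(O)c2c1` gives 18100 nM, the lower of the two numbers so far. Compound 2 `Cc1c(C(=O)Nc2ccc(-c3ccccc3)cc2)nc2ccccc2c1O`, without the methoxy, gives 37200 nM. The next structure is compound 3 `COc1ccc2nc(C(=O)Nc3ccc(-c4ccccc4)cc3)c(C)c(C(=O)O)c2c1`, with carboxy in place of hydroxy on an aromatic carbon, opposite the ring nitrogen and ortho to a methyl group: carboxy in place of hydroxy on an aromatic carbon. Going by the values given here, the only measured step is a 2.1-fold higher number from compound 1 to compound 2 (0.31 log units; beyond the scatter), with hydrogen in place of methoxy on an aromatic carbon. That step is modest and involves neither hydroxy nor carboxy, so it bears on the change only indirectly, as a gauge of how far one substitution has moved this read-out. Among the compounds with values here, no measured pair exchanges hydroxy for carboxy, which leaves the direction open. In this assay, a step of similar modest size is expected, leaning tentatively towards a higher number, though a wide range is needed. For compound 3 the expected value is 30000 nM, with an estimated range of 9000 nM to 90000 nM. This estimate means an expected 1.7-fold higher number from compound 1 to compound 3 (0.22 log units; within the scatter).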

Compound 3, half-maximal inhibitory concentration: 9430 nM
The estimate for compound 3 lay 3.2-fold (0.50 log units) above the measured number; measured number inside the range.
By their numbers in this assay, from the lowest: compounds 3 and 1 (each within the scatter of the next); then compound 2.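

At the position opposite the ring nitrogen, ortho to a methyl group, replacing hydroxy with carboxy leaves this assay without a resolved difference (a 1.9-fold lower number from compound 1 to compound 3 (0.28 log units; within the scatter)), so compound 1 and compound 3 cannot be ordered on this read-out. Hydroxy, with 1 heavy atom, and carboxy, with 3 heavy atoms and 1 double bond outside aromatic rings, therefore give numbers that cannot be told apart at this position, whereas the only step beyond the scatter remains the one at the methoxy site (a 2.1-fold higher number from compound 1 to compound 2 (0.31 log units; beyond the scatter)). Nothing available explains why this exchange stays within the scatter.

The two groups compared here do not show how far this position stays insensitive, and an amine, a methyl ester or a primary amide in the same place would test that on the same read-out. As far as these compounds go, the effect of removing the methoxy from the carboxy-bearing compound 3 also remains open, so it is unknown whether the step seen with hydroxy present carries over to the carboxy series.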